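The source may report more compounds than this note shows. Statements on the series, on what has been measured and on what is new or still open speak of the compounds shown alone.

Compound 1 `CCC1=C(O)c2c(oc(-c3ccc(Br)cc3)cc2=O)C(CC)(CC)C1=O`, compound 2 `CCC1=C(O)c2c(oc(-c3cc(C)c(OC)cc3C)cc2=O)C(CC)(CC)C1=O` and compound 3 `CCC1=C(O)c2c(oc(-c3ccc(OC)c(OC)c3OC)cc2=O)C(CC)(CC)C1=O` share one core and differ in the aryl group on it. In a functional assay on KBVIN cells (Homo sapiens) for antiproliferative activity, read by sulforhodamine B assay, with a stated time of 3 days (a higher number here means that more compound is needed for the effect, a lower number that less compound is needed), compound 1 gives 15.7 uM, the highest number of the three; compound 2 gives 7.58 uM and compound 3 gives 1.57 uM, each lying below compound 1 by more than the scatter. Compound 4 `CCC1=C(O)c2c(oc(-c3cc(C)c(O)c(C)c3)cc2=O)C(CC)(CC)C1=O` has not yet been measured in this assay. It differs from compound 1 in one place: 4-hydroxy-3,5-dimethylphenyl in place of 4-bromophenyl on an aromatic carbon. Because compound 2 at 7.58 uM and compound 3 at 1.57 uM both sit below compound 1, a downward step beyond the scatter is expected. Compound 4 is expected to give about 6 uM, in the range 2 uM to 18 uM. That estimate means a step of a 2.6-fold lower number from compound 1 to compound 4 (0.42 log units; beyond the scatter).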

Compound 4, concentration for half-maximal effect: 8.9 uM
The estimate for compound 4 lay 1.5-fold (0.17 log units) below the measured number, and the stated range covers the measured number.
By their numbers in this assay, from the lowest: compound 3; then compounds 2, 4 and 1 (each within the scatter of the next, the first and the last beyond it).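

In this assay the exchange of 4-bromophenyl for 4-hydroxy-3,5-dimethylphenyl gives a 1.8-fold lower number from compound 1 to compound 4 (0.25 log units; within the scatter) and so leaves the number unchanged as far as this assay can tell. This position therefore accepts an aryl group with a hydrogen-bond donor and acceptor, where 4-bromophenyl has neither, without a readable change. Nothing measured here bears on why the step stays this small. Going by these compounds, what remains open is how the hydroxyl and the two methyl groups each contribute alone, and what an amine or a carboxylic acid on this aryl ring would do.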